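The source may report more compounds than this note shows. Statements on the series, on what has been measured and on what is new or still open speak of the compounds shown alone.

Values in a functional assay on OVCAR-3 cells (Homo sapiens) for inhibition, read by sulforhodamine B assay, with a stated time of 48 h; a higher number here means a weaker inhibitor of growth, a lower number a stronger inhibitor of growth:
compound 1 `COc1ccc(/C=C/C2CC(=O)C=CO2)cc1OC`: 74.3 uM
compound 2 `COc1cc(/C=C/C2CC(=O)C=CO2)cc(OC)c1OC`: 85.4 uM
compound 3 `COc1ccc(/C=C/C2CC=CC(=O)O2)cc1OC`: 16.8 uM

Compound 4 `COc1cc(OC)c(OC)cc1/C=C/C1CC=CC(=O)O1` is not yet measured. Compound 3 gives the lowest number of the three; the difference between its core and the core of compound 1 is not broken down here. From compound 1 to compound 2 the change is methoxy in place of hydrogen on an aromatic carbon, and it made a step of a 1.1-fold higher number from compound 1 to compound 2 (0.06 log units; within the scatter) in this assay. The change from compound 3 to compound 4 is methoxy in place of hydrogen on an aromatic carbon; this is the same kind of change, not the same one, since the place differs: in compound 2 the entering methoxy sits ortho to a methoxy group and meta to the group of 9 heavy atoms, while in compound 4 it sits ortho to the group of 9 heavy atoms and para to a methoxy group. Because the earlier step of a 1.1-fold higher number from compound 1 to compound 2 (0.06 log units; within the scatter) lay within the scatter, a step of about a 1.2-fold higher number from compound 3 to compound 4 (0.08 log units; within the scatter) is expected in this assay, with wider room allowed for the different surroundings. Compound 4 is estimated at 20 uM, expected between 8 uM and 50 uM.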

Compound 4, concentration for growth inhibition (reported as GI): 7.2 uM
Beside the measured number, compound 4's estimate is 2.8-fold (0.44 log units) above it; measured number below the stated range.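

The entering methoxy gave a 2.3-fold lower number from compound 3 to compound 4 (0.37 log units; beyond the scatter) in this assay and so did not carry over in size from one core to the other: the same change on two cores in this assay, a 1.1-fold higher number (0.06 log units; within the scatter) from compound 1 to compound 2 and a 2.3-fold lower number (0.37 log units; beyond the scatter) from compound 3 to compound 4, 2.7-fold (0.43 log units) apart, beyond the scatter of two such steps.
The place also differs between the two steps, with the methoxy of compound 4 ortho to a group of 9 heavy atoms and para to a methoxy group, so these compounds do not separate the effect of core from that of place. For the compounds shown here, one pair per core shows only that the step on one core was a poor guide to the step on the other, and it gives no general rule.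

Open, going by these compounds, is whether methoxy placed as in compound 2 would behave alike on the core of compound 3. Also open, on these data alone, is how an amine or a carboxylic acid would compare with methoxy at the place filled in compound 4.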